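Replacing a Nitro Group with Methyl on a Hydrazone

The compounds below may be only part of what the source reports. "The series", "measured", "known", "first", "only" and "open" are said of these compounds alone.

Measured compounds:
- compound 1, `COc1cc(/C=N/NC(=O)COc2cccc3ccccc23)cc(OC)c1OC`: 3.26
- compound 2, `O=C(COc1cccc2ccccc12)N/N=C/c1ccc([N+](=O)[O-])cc1`: 3.97
- compound 3, `O=C(COc1cccc2ccccc12)N/N=C/c1c[nH]c2ccccc12`: 3.79

In a physicochemical assay for lipophilicity, measured as octanol-water partition (a higher number here means a more lipophilic compound, a lower number a more polar compound), compound 2 gives 3.97, the highest number among the three. Its gap to compound 3 is within the scatter, so the two cannot be told apart; its gap to compound 1 is beyond the scatter, so compound 2 does stand above compound 1 in this assay.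

The next compound, compound 4, `Cc1ccc(/C=N/NC(=O)COc2cccc3ccccc23)cc1`, has not yet been measured. Relative to compound 2 it differs in one place: methyl in place of nitro on an aromatic carbon. Among the measured compounds shown here, no pair of measured compounds shows this same change, so no measured step can be quoted for it.

Starting from the value of compound 2, 3.97, compound 4 is expected to come out higher, with a step of a number 0.63 log units higher from compound 2 to compound 4 (beyond the scatter) in this assay, beyond the scatter. The estimate for compound 4 is 4.6, with a range from 4.1 to 5.1.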

Compound 4, partition coefficient: 4.49
Compound 4: middle estimate off by 0.11 log units, on the high side, and the stated range covers the measured number.
By their numbers in this assay, from the lowest: compound 1; then compounds 3 and 2 (each within the scatter of the next); then compound 4.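

This is the first pair among the compounds shown that differs in only one place, so this aromatic carbon, para to a large group, now has a measured step. In this assay, methyl in place of nitro gives a number 0.52 log units higher from compound 2 to compound 4 (beyond the scatter) and places compound 4 at the top of the series. Nothing measured here explains the size or direction of this step, and a single pair cannot show which difference between the two groups matters.

On these data alone, it remains open whether an amine, a chlorine atom or a longer chain such as ethyl on the same carbon would land near compound 2, near compound 4 or elsewhere. As far as these compounds go, it is also open whether the same swap would give a similar step on a different core.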